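A few compounds are considered here, and "the series" means these few. Any claim that something is new, unique, unknown or untested is made for them only; others in the source may bear on it.

Working notes on the series. Three analogues share one core and differ only in the saturated ring and its nitrogen substituent on an aromatic nitrogen. Compound 1 `CN1CCN(c2ccc(Nc3ncc4nc(Nc5ccc(F)cc5)n([C@H]5CCCN(S(=O)(=O)C6CC6)C5)c4n3)cc2)CC1` gives 8.6 nM in a functional assay on HCC827 cells (Homo sapiens) for antiproliferative activity, read by MTT assay, with a stated time of 72 h; a higher number here means a weaker inhibitor, a lower number a stronger inhibitor. Compound 2 `CN1CCN(c2ccc(Nc3ncc4nc(Nc5ccc(F)cc5)n([C@@H]5CCN(S(=O)(=O)C6CC6)C5)c4n3)cc2)CC1` gives 2.5 nM in the same assay, a change of a 3.4-fold lower number from compound 1 to compound 2 (0.54 log units; beyond the scatter). Compound 3 `CN1CCN(c2ccc(Nc3ncc4nc(Nc5ccc(F)cc5)n([C@H]5CCN(C(=O)OC(C)(C)C)C5)c4n3)cc2)CC1` gives 580 nM, the highest number of the three: it stands a 67-fold higher number from compound 1 to compound 3 (1.83 log units; beyond the scatter) and a 230-fold higher number from compound 2 to compound 3 (2.37 log units; beyond the scatter).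

Compound 4 `CN1CCN(c2ccc(Nc3ncc4nc(Nc5ccc(F)cc5)n([C@@H]5CCCN(C(=O)CO)C5)c4n3)cc2)CC1` is not yet measured. Its change from compound 3 is 1-((hydroxymethyl)carbonyl)piperidin-3-yl in place of 1-(tert-butoxycarbonyl)pyrrolidin-3-yl on an aromatic nitrogen. For the measured compounds named here, two measured steps bear on it directly: the move from compound 3 back to compound 1 or compound 2 removes the tert-butoxycarbonyl group in favour of a cyclopropylsulfonyl group and gives a large drop in the number each time, while the pyrrolidine-to-piperidine exchange between compound 2 and compound 1 was only modest. The hydroxyacetyl group of compound 4 is neither of the substituents already tested, so the step is read from the two large ones with some caution. Compound 4 is therefore expected to show a large fall in the number, a 19-fold lower number from compound 3 to compound 4 (1.29 log units; beyond the scatter), and its estimated value is 30 nM, with a range of 8 nM to 150 nM.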

Compound 4, half-maximal inhibitory concentration: 66 nM
Compound 4: middle estimate off by 2.2-fold (0.34 log units), on the low side; the measured number falls inside the stated range.
By their numbers in this assay, from the lowest: compound 2; then compound 1; then compound 4; then compound 3.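

In this assay, the position accepts a carbonyl-linked substituent with a far lower number than the 1-(tert-butoxycarbonyl)pyrrolidin-3-yl group gives, an 8.8-fold lower number from compound 3 to compound 4 (0.94 log units; beyond the scatter), so the high number of compound 3 does not extend to every carbonyl-linked group on the ring nitrogen. The 1-((hydroxymethyl)carbonyl)piperidin-3-yl group still falls short of both cyclopropylsulfonyl analogues, a 7.7-fold higher number from compound 1 to compound 4 (0.89 log units; beyond the scatter) and a 26-fold higher number from compound 2 to compound 4 (1.42 log units; beyond the scatter), which places it in the middle of the four and shows that the substituent on the ring nitrogen separates compounds even when the six-membered ring is kept. No measured information on why these numbers differ is available here.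

Compound 1 and compound 4 are drawn with opposite configuration at the ring carbon on the aromatic nitrogen, so their step does not separate the nitrogen substituent from the stereocentre, and the mirror-image partner of either compound would be needed to settle this. On these data alone, it also remains open whether the hydroxyl matters, which a plain acetyl group, an aminoacetyl group or a longer hydroxyalkanoyl chain on the same ring nitrogen would test.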